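Series notes: from compound 3 to compound 4

A few compounds are considered here, and "the series" means these few. Any claim that something is new, unique, unknown or untested is made for them only; others in the source may bear on it.

Compound 3 `Cc1c(C(=O)/C=C/c2ccc(Cl)c(Cl)c2)[n+]([O-])c2ccccc2[n+]1[O-]` gives 84000 nM in a functional assay on HSC-3 cells (Homo sapiens) for cytotoxicity, with a stated time of 48 h (on this read-out higher numbers stand for lower toxicity in this test and lower numbers for higher toxicity in this test), the second highest of the three numbers. Compound 1 `Cc1c(C(=O)/C=C/c2cccc([N+](=O)[O-])c2)[n+]([O-])c2ccccc2[n+]1[O-]` gives 122000 nM in this assay, and compound 2 `Cc1c(C(=O)/C=C/c2ccc(Cl)cc2)[n+]([O-])c2ccccc2[n+]1[O-]` gives 38000 nM. Compound 4 `Cc1c(C(=O)/C=C/c2ccc(F)cc2)[n+]([O-])c2ccccc2[n+]1[O-]` differs from compound 3 by 4-fluorophenyl in place of 3,4-dichlorophenyl on a double-bonded chain carbon bound to a double-bonded chain carbon. Among the compounds with values here, only one measured step bears on this change: a 2.2-fold higher number from compound 2 to compound 3 (0.34 log units; beyond the scatter), which was modest but beyond the scatter. Compound 4 removes that added chloro and exchanges the remaining chloro for fluoro, so a step of roughly that size in the opposite direction is expected, landing near the value of compound 2. In this assay compound 4 is estimated at 50000 nM, with a range from 20000 nM to 125000 nM. The expected step is a 1.7-fold lower number from compound 3 to compound 4 (0.23 log units; within the scatter).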

Compound 4, half-maximal cytotoxic concentration: 7700 nM
The estimate for compound 4 lay 6.5-fold (0.81 log units) above the measured number; measured number below the stated range.
By their numbers in this assay, from the lowest: compound 4; then compound 2; then compounds 3 and 1 (each within the scatter of the next).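

Fluoro in place of chloro on an aromatic carbon gives a 4.9-fold lower number from compound 2 to compound 4 (0.69 log units; beyond the scatter) in this assay, so the identity of this one halogen shifts the number well beyond the scatter. The full change from 3,4-dichlorophenyl to 4-fluorophenyl gives an 11-fold lower number from compound 3 to compound 4 (1.04 log units; beyond the scatter) and is much larger than the earlier chloro step. Nothing available accounts for the size of the fluoro step.

Open, from the compounds shown here alone, is whether an amine or a methoxy group in place of the fluoro would keep the number low or return it towards the chloro value.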